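The source may hold more compounds than are shown below. What is called first, only, known or untested is meant among the compounds shown, and "the series" means these compounds.

Measured so far:
compound 1, `Brc1ccccc1OCC1=NCCO1`: 20%
compound 2, `Cc1cc(OCC2=NCCO2)ccc1Cl`: 30%

Both numbers come from a toxicity assay on the whole organism with Rattus norvegicus as the target, at a dose of 200 mg/kg by the oral route; a higher number here means a stronger effect of the compound at the dose given, a lower number a weaker effect. In this assay compound 1 gives 20% and compound 2 gives 30%. These two values lie within the scatter of each other, so neither compound can be called weaker or stronger than the other; compound 1 stands together with compound 2 at a modest level of effect, and that pair of alike numbers is all the measured ground there is.

Compound 3, `O=[N+]([O-])c1ccccc1OCC1=NCCO1`, has not yet been measured. It differs from compound 1 in one place: nitro in place of bromo on an aromatic carbon. Going by the values given here, no measured pair shows what this swap does in this assay, so there is no step to lean on. Working only from the two alike values, the expected step is a number 5 percentage points higher from compound 1 to compound 3 (within the scatter), small and with no direction beyond the scatter. Compound 3 is therefore estimated to give about 25% in this assay, most likely between 5% and 50%.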

Compound 3, a percentage reported as activity, at one dose (the size of the read-out at that dose, not a potency): 25%
The estimate for compound 3 equals the measured number at the digits printed; low and high end bracket the measured number.
By their numbers in this assay, from the lowest: compounds 1, 3 and 2 (each within the scatter of the next).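

Placing nitro instead of bromo on this aromatic carbon, ortho to a group of 7 heavy atoms, gives in this assay a number 5 percentage points higher from compound 1 to compound 3 (within the scatter), so this is the first direct comparison at this position, and the two groups cannot be told apart here. The change swaps 1 heavy atom for 3 and adds 2 hydrogen-bond acceptors, yet these differences in what is counted do not separate the two compounds in this read-out. Nothing available explains why the two compounds read alike.

On these data alone, what an amine or a carboxylic acid on this carbon would give in this assay stays open, as does whether any group here can move the number beyond the scatter. Whether nitro would read the same at another place on the ring is also unanswered.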